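The source may report more compounds than this note shows. Statements on the series, on what has been measured and on what is new or still open speak of the compounds shown alone.

Of the compounds shown here, three built around one shared core have been measured in a functional assay on MDA-MB-435 cells (Homo sapiens) for inhibition, read by sulforhodamine B assay, with a stated time of 48 h; on this read-out lower numbers stand for stronger inhibition and higher numbers for weaker inhibition. Compound 1, `O=C(Nc1cccc(-n2cc(-c3ccncc3)c(-c3ccc(Cl)c(O)c3)n2)c1)Nc1cccc(C(F)(F)F)c1`, gives 1490 nM. Compound 2, `COc1cc(-c2nn(-c3cccc(NC(=O)Nc4cc(C(F)(F)F)cc(C(F)(F)F)c4)c3)cc2-c2ccncc2)ccc1Cl`, gives 890 nM in this assay, and compound 3, `COc1cc(-c2nn(-c3cccc(NC(=O)Nc4cccc(C(F)(F)F)c4)c3)cc2-c2ccncc2)ccc1Cl`, gives 870 nM. Among these three numbers compound 2 stands second highest, with compound 3 nearest and compound 1 furthest; both gaps lie within the scatter, so the three cannot be ranked against one another.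

Compound 4, `O=C(Nc1cccc(-n2cc(-c3ccncc3)c(-c3ccc(Cl)c(O)c3)n2)c1)Nc1cc(C(F)(F)F)cc(C(F)(F)F)c1`, has not yet been measured in this assay. It differs from compound 2 in one place: hydrogen in place of methyl on an oxygen on an aromatic ring. Within the data shown here, one measured step bears on this, run in the opposite direction: from compound 1 to compound 3 the methyl entered in place of hydrogen on the aromatic oxygen, and a 1.7-fold lower number from compound 1 to compound 3 (0.23 log units; within the scatter). Reversing that change for compound 4 therefore points to no step beyond the scatter, or at most a slightly higher number. On that basis the expectation is a 1.6-fold higher number from compound 2 to compound 4 (0.20 log units; within the scatter) in this assay. The estimated value for compound 4 is 1400 nM, with a range from 700 nM to 3000 nM.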

Compound 4, half-maximal inhibitory concentration: 910 nM
Beside the measured number, compound 4's estimate is 1.5-fold (0.19 log units) above it, and the stated range covers the measured number.
By their numbers in this assay, from the lowest: compounds 3, 2, 4 and 1 (each within the scatter of the next).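

Methoxy to hydroxy on the 4-chloro-3-methoxyphenyl group can now be read on a second core, where it gives a 1.0-fold higher number from compound 2 to compound 4 (0.01 log units; within the scatter) in this assay, so on neither core can the hydroxy and methoxy forms be told apart, and the two readings agree: the same change on two cores in this assay, a 1.7-fold lower number (0.23 log units; within the scatter) from compound 1 to compound 3 and a 1.0-fold lower number (0.01 log units; within the scatter) from compound 4 to compound 2, 1.7-fold (0.22 log units) apart, within the scatter of two such steps

The added trifluoromethyl can also now be read on a second core, the one carrying the hydroxy group, where it gives a 1.6-fold lower number from compound 1 to compound 4 (0.21 log units; within the scatter), and this reading agrees with the one on the methoxy core: the same change on two cores in this assay, a 1.0-fold lower number (0.01 log units; within the scatter) from compound 2 to compound 3 and a 1.6-fold higher number (0.21 log units; within the scatter) from compound 4 to compound 1, 1.7-fold (0.22 log units) apart, within the scatter of two such steps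

Across these four compounds, then, neither change moves the number beyond the scatter on either core, and hydrogen and methyl on this oxygen give results that cannot be separated.

The compounds shown leave open whether any group on this oxygen would move the number beyond the scatter, for example a longer chain such as propyl or a chain ending in an amine. They also leave open whether replacing the trifluoromethyl with a carboxylic acid would shift the number on either core.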